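The source may report more compounds than this note shows. Statements on the series, on what has been measured and on what is new or still open speak of the compounds shown alone.

Compound 1 `CCOC(=O)c1nn(C)c2c1CN(C(=O)Nc1ccc(Cl)cc1)CC2`, compound 2 `Cn1nc(COc2cc(F)cc(F)c2)c2c1CCN(C(=O)Nc1ccc(Br)cc1)C2` and compound 3 `Cn1nc(COc2cc(F)cc(F)c2)c2c1CCN(C(=O)NC(=O)c1ccccc1)C2` make up the measured set. In an assay on cells for inhibition of Pendrin (Mus musculus), read by fluorescence, with a stated time of 10 min (on this read-out higher numbers stand for weaker inhibition and lower numbers for stronger inhibition), compound 1 reaches only the limit > 10000 nM. Compound 2 gives 3300 nM in this assay. Compound 3 likewise stops at the limit > 10000 nM. Within the data shown here, compound 2 therefore holds the only real number in this assay, while the other two values are limits, as the limit of > 10000 nM in this assay, at which 2 of the 3 values shown sit, records. Compound 4 `Cn1nc(COc2cc(F)cc(F)c2)c2c1CCN(C(=S)Nc1ccc(Cl)cc1)C2` differs from compound 2 by a group of 10 heavy atoms (7 carbon, 1 nitrogen, 1 sulfur, 1 chlorine; one six-membered aromatic ring of carbon only) in place of a group of 10 heavy atoms (7 carbon, 1 nitrogen, 1 oxygen, 1 bromine; one six-membered aromatic ring of carbon only), on an amine nitrogen in a ring. Among the measured compounds shown here, the one measured step, an at least 3.0-fold higher number from compound 2 to compound 3 (0.48 log units; beyond the scatter), is a different kind of change and offers only a loose guide. A step of a 1.2-fold higher number from compound 2 to compound 4 (0.08 log units; within the scatter) is expected, with no firm direction. Compound 4 is estimated at 4000 nM, within 1500 nM to 12000 nM.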

Compound 4, half-maximal inhibitory concentration: > 10000 nM
Compound 4: a limit, no number (the forecaster's own chance of this, stated with the estimate: 30%); at least 2.5-fold (0.39 log units) between middle value and limit.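

At the amine nitrogen in a ring, the group carrying sulfur and chlorine in place of (4-bromophenyl)carbamoyl gives an at least 3.0-fold higher number from compound 2 to compound 4 (0.48 log units; beyond the scatter) in this assay. So a change that keeps the heavy-atom count and the aromatic ring still costs inhibition here, as the benzoyl change did. Compound 4 gives only a limit, which leaves compound 2 alone with a real number: the limit of > 10000 nM in this assay, at which 3 of the 4 values shown sit.

Oxygen and bromine change together, so the compounds shown cannot separate the effect of sulfur from that of chlorine. From the compounds shown here alone, how a methoxy group on the phenyl ring would fare stays open.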